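Swapping Methyl for Fluoro on a Salicylanilide Core

The source may hold more compounds than are shown below. What is called first, only, known or untested is meant among the compounds shown, and "the series" means these compounds.

Of the compounds shown here, three have been measured in a functional assay on HL-60 cells (Homo sapiens) for cytotoxicity, read by luminescence and CellTiter-Glo, with a stated time of 3 days; on this read-out higher numbers stand for weaker inhibition and lower numbers for stronger inhibition. Compound 1 `CN(C(=O)c1cc(F)ccc1O)c1ccc(C#N)cc1` carries a fluoro group and a methylated amide; in this assay compound 1 reaches only the limit > 10000 nM, so no number is known for it. Compound 2 `O=C(Nc1ccccc1)c1cc(F)ccc1O` also carries a fluoro group but lacks the nitrile; in this assay compound 2 likewise reaches only the limit > 10000 nM. Among the measured compounds shown here, compound 3 `Cc1ccc(O)c(C(=O)Nc2ccc(C#N)cc2)c1` is the sole compound with a real number: in this assay compound 3 gives 3920 nM, while the two others sit at the limit of > 10000 nM in this assay, at which 2 of the 3 values shown sit. Compound 4 `N#Cc1ccc(NC(=O)c2cc(F)ccc2O)cc1` is not yet measured. It differs from compound 3 in one place: fluoro in place of methyl on an aromatic carbon.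

For the measured compounds named here, no measured pair differs in this single change, so its effect cannot be read directly. The two fluoro-bearing compounds both stop at the limit, but each also differs from compound 4 elsewhere. The step from compound 3 to compound 4 is expected to be small, a 1.4-fold higher number from compound 3 to compound 4 (0.15 log units; within the scatter), at the edge of the usual scatter. Compound 4 is therefore estimated at 5500 nM, within a range from 1800 nM to 16000 nM.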

Compound 4, half-maximal inhibitory concentration: 1420 nM
The estimate for compound 4 lay 3.9-fold (0.59 log units) above the measured number; the whole stated range lies above it.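

In this assay, the change at this position, para to a hydroxy group, can now be read directly: a 2.8-fold lower number from compound 3 to compound 4 (0.44 log units; beyond the scatter), so fluoro in place of methyl gives stronger inhibition here. Compound 4 also shows that two other places on the shared core count, with the nitrile in an at least 7.0-fold lower number from compound 2 to compound 4 (0.84 log units; beyond the scatter) and the amide hydrogen in an at least 7.0-fold lower number from compound 1 to compound 4 (0.84 log units; beyond the scatter). Both of these steps give only a minimum size, since compounds 1 and 2 have no real number: the limit of > 10000 nM in this assay, at which 2 of the 4 values shown sit.

The compounds shown compare only methyl and fluoro at this position, so what a chloro or a methoxy group there would give stays open. All four compounds also keep the hydroxy group, so its share in these values cannot be read, and the data give no reason why fluoro lowers the number.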